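Swapping the aryl group on the imine carbon of compound 2

The compounds below may be only part of what the source reports. "The series", "measured", "known", "first", "only" and "open" are said of these compounds alone.

Three compounds share one core and differ only in the group on a carbon with a double bond to nitrogen. In a functional assay on HeLa cells (Homo sapiens) for cytotoxicity, read by MTT assay, with a stated time of 48 h, tested at 25 uM (on this read-out higher numbers stand for a stronger effect at the one concentration tested and lower numbers for a weaker effect), compound 1 `CSc1ccc(/C=N/n2c(Cc3ccc(S(C)(=O)=O)cc3)n[nH]c2=S)cc1` gives 32.7%, compound 3 `COc1ccc2cc(/C=N/n3c(Cc4ccc(S(C)(=O)=O)cc4)n[nH]c3=S)ccc2c1` gives 42%, and compound 2 `CS(=O)(=O)c1ccc(Cc2n[nH]c(=S)n2/N=C/c2c(F)cccc2Cl)cc1` gives 55.3%. On these numbers compound 2 stands highest, clear of the scatter against both neighbours. Within the data shown here, the only measured step at this position is a number 22.6 percentage points higher from compound 1 to compound 2 (beyond the scatter), which shows that the group here does move the read-out. Compound 4 `CS(=O)(=O)c1ccc(Cc2n[nH]c(=S)n2/N=C/c2cccs2)cc1` differs from compound 2 by thiophen-2-yl in place of 2-chloro-6-fluorophenyl on a carbon with a double bond to nitrogen. Among the measured compounds shown here, no measured step involves thiophen-2-yl, so the direction of this change cannot be read from the data; the three aryl groups measured so far span a modest range, and compound 2 sits at its top. The expectation for compound 4 in this assay is therefore a drop of roughly a number 15.3 percentage points lower from compound 2 to compound 4 (beyond the scatter), landing near the middle of the measured spread. Compound 4 is estimated at 40%, with a likely range from 25% to 55%.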

Compound 4, a percentage reported as activity, at one concentration (the size of the read-out at that concentration, not a potency): 33.3%
Compound 4: the middle estimate sits 6.7 percentage points above what was measured; measured number inside the range.
By their numbers in this assay, from the lowest: compounds 1, 4 and 3 (each within the scatter of the next); then compound 2.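

In this assay, replacing the 2-chloro-6-fluorophenyl group with thiophen-2-yl gives a number 22 percentage points lower from compound 2 to compound 4 (beyond the scatter), so a second, different group now falls clearly short of compound 2. The other new comparison gives a number 0.6 percentage points higher from compound 1 to compound 4 (within the scatter), which means that thiophen-2-yl and 4-(methylsulfanyl)phenyl cannot be told apart on this read-out, although one is a five-membered ring and the other a six-membered ring. Among the groups compared directly at this position, only 2-chloro-6-fluorophenyl now stands clear, and no evidence here accounts for the difference.

The compounds shown leave open whether both the chlorine and the fluorine are needed, since a phenyl ring carrying only one of these atoms, or neither, does not appear among them. They also do not show what an amine or a carboxylic acid on the ring would do at this position.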